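The source may report more compounds than this note shows. Statements on the series, on what has been measured and on what is new or still open speak of the compounds shown alone.

Compound 1 `Cn1c(Cc2nn(C)c(=O)c3ccccc23)nnc1SCCCCCCCC(=O)Nc1ccc(F)cc1F`: in an assay on isolated protein (Mus musculus) for inhibition of IL15-IL15 receptor (Homo sapiens), read by resazurin assay, with stated times of 30 min and 2.5 days (a higher number here means a weaker inhibitor, a lower number a stronger inhibitor), compound 1 gives 2300 nM.
Compound 2 `COc1ccc(NC(=O)CCCCCCCSc2nnc(Cc3nn(C)c(=O)c4ccccc34)n2C)cc1`: in this assay compound 2 gives 3900 nM.
Compound 3 `Cn1c(Cc2nn(C)c(=O)c3ccccc23)nnc1SCCCCCCCC(=O)Nc1ccccc1O`: in this assay compound 3 gives 27000 nM.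

Compound 3 has the highest number of the three, set apart from both others: a 12-fold higher number from compound 1 to compound 3 (1.07 log units; beyond the scatter) and a 6.9-fold higher number from compound 2 to compound 3 (0.84 log units; beyond the scatter). Compound 4 `Cn1c(Cc2nn(C)c(=O)c3ccccc23)nnc1SCCCCCCCC(=O)Nc1ccc(O)cc1` differs from compound 3 only in the arrangement of the same atoms: 4-hydroxyphenyl in place of 2-hydroxyphenyl on an amide-type nitrogen. Among the measured compounds shown here, no measured step moves a hydroxyl between these positions, so the evidence is indirect. The two steps into compound 3 show that the 2-hydroxyphenyl gave the weakest result, while a 1.7-fold higher number from compound 1 to compound 2 (0.23 log units; within the scatter) shows a 4-methoxyphenyl close to the difluorophenyl. The expectation is that compound 4 sits below compound 3 in this assay, a modest step of a 3.4-fold lower number from compound 3 to compound 4 (0.53 log units; beyond the scatter), with wide uncertainty. Compound 4 is estimated at 8000 nM, between 2500 nM and 25000 nM.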

Compound 4, half-maximal inhibitory concentration: > 30000 nM
Compound 4: a limit, no number; the forecaster's own chance of this, stated with the estimate: 5%; middle value at least 3.7-fold (0.57 log units) from the limit.
By their numbers in this assay, from the lowest: compounds 1 and 2 (each within the scatter of the next); then compound 3. At a limit, above all of these: compound 4.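

Compound 4 reads only as a limit of the assay, not a number: the limit of > 30000 nM in this assay, at which 1 of the 4 values shown sits.

Like the 2-hydroxyphenyl, the 4-hydroxyphenyl on the amide-type nitrogen gives a clear loss, with an at least 13-fold higher number from compound 1 to compound 4 (1.11 log units; beyond the scatter) and an at least 7.6-fold higher number from compound 2 to compound 4 (0.88 log units; beyond the scatter); in the second step, hydrogen simply replaces methyl on the oxygen. The two hydroxyphenyl compounds cannot be ranked, since an at least 1.1-fold higher number from compound 3 to compound 4 (0.04 log units; that floor lies within the scatter) leaves only a floor.

As far as these compounds go, how far compound 4 actually lies beyond its limit remains open. So does whether an aminophenyl or a carboxyphenyl on this nitrogen would fare any better than the hydroxyphenyl groups.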